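Removing the Methyl From a Sulfonyl Hydroxyguanidine

The compounds below may be only part of what the source reports. "The series", "measured", "known", "first", "only" and "open" are said of these compounds alone.

Compound 1 `Cc1ccc(S(=O)(=O)NC(=O)Nc2ccc(Cl)cc2)cc1` and compound 2 `Cc1ccc(S(=O)(=O)N/C(=N\O)Nc2ccc(Cl)cc2)cc1` share the same core. For the measured compounds named here, in a functional assay on HepG2 cells (Homo sapiens) for cytotoxicity (on this read-out lower numbers stand for stronger inhibition and higher numbers for weaker inhibition), compound 2 gives 49 ug/mL, the only number among the two values shown. For compound 1 the value > 300 ug/mL is a limit of the assay rather than a number, as recorded in the limit of > 300 ug/mL in this assay, at which 1 of the 2 values shown sits. Compound 3 `O=S(=O)(N/C(=N\O)Nc1ccc(Cl)cc1)c1ccccc1` differs from compound 2 by hydrogen in place of methyl on an aromatic carbon. Going by the values given here, no step between measured compounds is available here, so in this assay a step of a 1.3-fold higher number from compound 2 to compound 3 (0.12 log units; within the scatter) is expected, small and toward a slightly higher number, hardly beyond the usual scatter. Compound 3 is accordingly estimated at 65 ug/mL, between 25 ug/mL and 170 ug/mL.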

Compound 3, half-maximal inhibitory concentration: 54 ug/mL
Estimate against measurement, compound 3: 1.2-fold (0.08 log units) above; measured number inside the range.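

For the compounds shown here, replacing the methyl on the aromatic carbon para to a large group with hydrogen gives, in this assay, a 1.1-fold higher number from compound 2 to compound 3 (0.04 log units; within the scatter) and so offers the first reading at this position. On this read-out, the change from 4-methylphenyl to phenyl leaves compound 2 and compound 3 indistinguishable. Nothing on record bears on why this is so. As far as these compounds go, whether an amine, a methoxy group or a carboxylic acid at this place would also read within the scatter remains open. So does how such a group would behave on a longer chain.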